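A Sulfanyl Group in Place of an Ether Chain

This account rests on a few compounds, and the source may have more. Where it says the series, first, only, none or still open, it means among the compounds named here.

compound 1 `CCCCN(C)c1nc(C(C)(C)C)ccc1CNC(=O)C(C)c1ccc(NS(C)(=O)=O)c(F)c1`: 1.2 nM
compound 2 `CCOCCOc1nc(C(C)(C)C)ccc1CNC(=O)C(C)c1ccc(NS(C)(=O)=O)c(F)c1`: 23.9 nM

Of the compounds shown here, two have so far been measured in an assay on cells for antagonist activity at transient receptor potential cation channel subfamily V member 1 (Homo sapiens), read by FLIPR and calcium flux, with a stated time of 6 min; a higher number here means a weaker inhibitor, a lower number a stronger inhibitor. Compound 1 `CCCCN(C)c1nc(C(C)(C)C)ccc1CNC(=O)C(C)c1ccc(NS(C)(=O)=O)c(F)c1` gives 1.2 nM, and compound 2 `CCOCCOc1nc(C(C)(C)C)ccc1CNC(=O)C(C)c1ccc(NS(C)(=O)=O)c(F)c1` gives 23.9 nM. Compound 2 stands highest of the two numbers; its nearest neighbour is compound 1, reached by a 20-fold higher number from compound 1 to compound 2 (1.30 log units; beyond the scatter) with 2-ethoxyethoxy in place of butyl(methyl)amino on an aromatic carbon.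

Compound 3 `COc1ccc(CSc2nc(C(C)(C)C)ccc2CNC(=O)C(C)c2ccc(NS(C)(=O)=O)c(F)c2)cc1` has not yet been measured. Its change from compound 2 is (4-methoxybenzyl)sulfanyl in place of 2-ethoxyethoxy on an aromatic carbon. Going by the values given here, the only measured step at this position is the one from compound 1 to compound 2, which was large, so the site clearly tolerates little without consequence, but neither measured group resembles the incoming one. The direction is therefore uncertain; a modest lowering is expected, a 3.0-fold lower number from compound 2 to compound 3 (0.48 log units; beyond the scatter). Compound 3 is estimated at 8 nM, within 2 nM to 35 nM.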

Compound 3, inhibition constant: 3.5 nM
Compound 3: middle estimate off by 2.3-fold (0.36 log units), on the high side; low and high end bracket the measured number.
By their numbers in this assay, from the lowest: compound 1; then compound 3; then compound 2.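

In this assay, a group carrying a six-membered aromatic ring of carbon only is accepted on this aromatic carbon next to the ring nitrogen: (4-methoxybenzyl)sulfanyl in place of 2-ethoxyethoxy gives a 6.8-fold lower number from compound 2 to compound 3 (0.83 log units; beyond the scatter) and so wins back much of the ground that separated the ether chain from butyl(methyl)amino. Set against butyl(methyl)amino, the same group still shows a 2.9-fold higher number from compound 1 to compound 3 (0.46 log units; beyond the scatter) and compound 1 remains the strongest inhibitor of the three. Nothing at hand bears on why these groups differ.

The compounds shown leave open whether the sulfur, the benzyl ring or its methoxy group carries the step, as none of them changes one of these alone. A plain benzylsulfanyl, a benzyloxy or a benzylamino group would separate those parts, and dimethylamino would test how much of the butyl chain compound 1 needs.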